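Halogen exchange on the benzyl ring, in two arrangements

The source may report more compounds than this note shows. Statements on the series, on what has been measured and on what is new or still open speak of the compounds shown alone.

Compound 1, `C=C(Br)C(=O)Nc1cccc(/C=C2\SC(=O)N(Cc3ccc(Cl)cc3)C2=O)c1`: 2700 nM
Compound 2, `C=C(Br)C(=O)Nc1cccc(/C=C2\SC(=O)N(Cc3ccc(F)cc3)C2=O)c1`: 800 nM
Compound 3, `C=C(Br)C(=O)Nc1ccc(/C=C2\SC(=O)N(Cc3cccc(Cl)c3)C2=O)cc1`: 8900 nM

These three compounds were measured in a functional assay on HeLa cells (Homo sapiens) for cytotoxicity, read by cell counting, with a stated time of 4 days; on this read-out higher numbers stand for weaker inhibition and lower numbers for stronger inhibition. Compound 1 and compound 2 differ in a single place, (fluoro in place of chloro on an aromatic carbon), and that exchange produced a 3.4-fold lower number from compound 1 to compound 2 (0.53 log units; beyond the scatter). Compound 3 is built from the same atoms as compound 1, joined differently; the difference between the two cores is not broken down here. Compound 3 gives the highest number of the three in this assay.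

Compound 4, `C=C(Br)C(=O)Nc1ccc(/C=C2\SC(=O)N(Cc3cccc(F)c3)C2=O)cc1`, has not yet been measured. It relates to compound 3 as compound 2 relates to compound 1: fluoro in place of chloro on an aromatic carbon. The surroundings are not identical, though: in compound 1 the exchanged atom sits para to a large group, whereas in compound 3 it sits meta to a large group, so this is the same kind of change rather than the same change. Because the earlier exchange gave a 3.4-fold lower number from compound 1 to compound 2 (0.53 log units; beyond the scatter), a step of similar direction is expected here, estimated as a 2.5-fold lower number from compound 3 to compound 4 (0.41 log units; beyond the scatter). Compound 4 is accordingly expected near 3500 nM, between 1200 nM and 10000 nM.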

Compound 4, half-maximal inhibitory concentration: 5900 nM
The estimate for compound 4 lay 1.7-fold (0.23 log units) below the measured number; the range from low to high includes it.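

In this assay, fluoro in place of chloro on the 3-chlorobenzyl group gives a 1.5-fold lower number from compound 3 to compound 4 (0.18 log units; within the scatter), a step too small to separate the two compounds on this core. Set beside the earlier exchange, this step cannot be distinguished from it: the same change on two cores in this assay, a 3.4-fold lower number (0.53 log units; beyond the scatter) from compound 1 to compound 2 and a 1.5-fold lower number (0.18 log units; within the scatter) from compound 3 to compound 4, 2.2-fold (0.35 log units) apart, within the scatter of two such steps. The two cores therefore show no measurable disagreement, but this does not establish that the change carries over with the same size, since only the first step stands beyond the scatter, and a single pair on each core, with the halogen placed differently in each, cannot separate a role of the core from a role of the halogen's place on the ring.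

Going by these compounds, whether a methoxy group, a nitrile or an amine in place of the halogen on the benzyl ring would follow the same course remains open. Also open, on these data alone, is how either halogen would behave at the other ring place on the same core.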